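From methylamino to 2-methoxyphenyl on the shared core

The source may report more compounds than this note shows. Statements on the series, on what has been measured and on what is new or still open speak of the compounds shown alone.

In a physicochemical assay for lipophilicity, at pH 7.4 (a higher number here means a more lipophilic compound, a lower number a more polar compound), compound 1 `O=C(NCc1ccc(Cl)cc1)c1ncc2cccnc2c1O` gives "not determined" (no result reported) and so offers no comparison. Among the compounds with values here, compound 2 `CNc1ccnc2c(O)c(-c3nc(C)n[nH]3)ncc12` stands at -0.2 as the only number so far. Compound 3 `COc1ccccc1-c1ccnc2c(O)c(-c3nc(C)n[nH]3)ncc12` keeps the core of compound 2 and carries 2-methoxyphenyl in place of methylamino on an aromatic carbon with the site opposite the ring nitrogen. Within the data shown here, no step between measured compounds is available for calibration, so the expectation rests on the structural change alone and remains loose. In this assay an upward move well beyond the scatter is expected. The estimated move is a number 1.40 log units higher from compound 2 to compound 3 (beyond the scatter) in size. For compound 3 the estimate is 1.2 with an expected range from 0.4 to 2 around it.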

Compound 3, distribution coefficient: 3.2
Compound 3: middle estimate off by 2.00 log units, on the low side, and the stated range ends below it.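

In this assay, 2-methoxyphenyl in place of methylamino on an aromatic carbon, at the site opposite the ring nitrogen, gives a number 3.40 log units higher from compound 2 to compound 3 (beyond the scatter), so a single exchange at this place on the shared core can move the read-out well beyond the scatter. The step is a joint one: a six-membered aromatic ring of carbon only enters while the hydrogen-bond donor of methylamino leaves, and this one pair cannot divide the shift between those two differences. Nothing available bears on why the step has this size.

Open, going by these compounds, is how an unsubstituted phenyl or a dimethylamino group at the same place would read in this assay, either of which would help to separate those differences. A single step also leaves open whether the shift would carry over to another core.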